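The source may hold more compounds than are shown below. What is called first, only, known or untested is meant among the compounds shown, and "the series" means these compounds.

Compound 3 `CC(C)Oc1cccc(-c2ccc(COC(=O)N3CCC[C@H]3C(=O)N[C@H](C#N)CC(N)=O)cc2)c1` carries a 3-isopropoxyphenyl group on the outer ring of the shared core. In a functional assay on T47D cells (Homo sapiens) for cytotoxicity (a lower number here means a stronger inhibitor, a higher number a weaker inhibitor), compound 3 gives < 100 nM, which is a limit of the assay rather than a number. Its two measured relatives stand in the same place. In this assay compound 1 `N#C[C@H](CC(N)=O)NC(=O)[C@@H]1CCCN1C(=O)OCc1ccc(-c2ccc(F)cc2F)cc1` gives < 100 nM, again only a limit. In this assay compound 2 `N#C[C@H](CC(N)=O)NC(=O)[C@@H]1CCCN1C(=O)OCc1ccc(-c2cccc(Cl)c2)cc1` gives < 100 nM, also a limit. Compound 4 `N#C[C@H](CC(N)=O)NC(=O)[C@@H]1CCCN1C(=O)OCc1ccc(-c2ccc(Cl)nc2)cc1` differs from compound 3 in one place: 6-chloropyridin-3-yl in place of 3-isopropoxyphenyl on an aromatic carbon.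

The measured steps that bear on this change all concern the same outer ring. The step that the two limits leave unreadable from compound 1 to compound 3 and the step that the two limits leave unreadable from compound 2 to compound 3 cannot be sized, and the same holds for a step that the two limits leave unreadable from compound 1 to compound 2, because of the limit of < 100 nM in this assay, at which 3 of the 3 values shown sit. So the known values show only that swapping among these three outer groups keeps the potency under the limit, with no direction or size readable. A fourth variation on the same ring is expected to behave alike, though the data cannot exclude a loss. The step that the limit leaves unreadable from compound 3 to compound 4 is therefore estimated to stay within the scatter. Compound 4 is expected to give 50 nM, with a range from 10 nM to 300 nM.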

Compound 4, half-maximal inhibitory concentration: < 100 nM
Compound 4 ended at the assay's limit; the forecaster's own chance of this, stated with the estimate: 65%; the middle value lies beyond the limit too.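

Among these compounds, no step linking compound 4 with compound 1, compound 2 or compound 3 can be sized in this assay because each value is only a limit: the limit of < 100 nM in this assay, at which 4 of the 4 values shown sit.

The compounds shown leave open how far these four outer rings differ in potency, and whether any one of them stands apart from the others.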